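This account rests on a few compounds, and the source may have more. Where it says the series, first, only, none or still open, it means among the compounds named here.

Measured compounds:
- compound 1 `Cc1cc(C)c(CN2CCc3c(Cl)cc([C@@H](CO)[C@@H]4CCCO4)c(Cl)c3C2=O)c(=O)[nH]1`: 4.3 10^-6 cm/s
- compound 2 `COc1cc(C)[nH]c(=O)c1CN1CCc2c(Cl)cc([C@@H](O)C3COC3)c(Cl)c2C1=O`: 1.2 10^-6 cm/s

In an ADME assay on MDCK cells (Canis lupus familiaris) for permeability, read by LC-MS, with a stated time of 90 min, tested at 2 uM (on this read-out higher numbers stand for higher permeability and lower numbers for lower permeability), compound 1 gives 4.3 10^-6 cm/s, the higher of the two numbers recorded so far. Within the data shown here, its nearest neighbour is compound 2, which in this assay gives 1.2 10^-6 cm/s; the gap between the two values lies beyond the usual scatter of such measurements, but as the two compounds differ in more than one place, no single structural step is recorded between them.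

Compound 3 `Cc1cc(C)c(CN2CCc3c(Cl)cc([C@H](CO)[C@H]4CCCO4)c(Cl)c3C2=O)c(=O)[nH]1` is the unmeasured partner of compound 1. The change between them is described as follows: the two compounds have the same atoms and bonds and differ only in configuration as drawn: 2 of 2 stereo elements differ (all stereocentres are inverted: mirror images); a stereocentre at a saturated chain carbon is drawn S in compound 1 and R in compound 3; a stereocentre at a saturated ring carbon is drawn S in compound 1 and R in compound 3. The core, the substituents and their places are all unchanged; only the drawn configuration at the two stereocentres is reversed. Among the measured compounds shown here, for an assay of this kind, which measures passage across a cell monolayer, no recorded step exists on which a difference between such mirror-image pairs could be read, so no step beyond the scatter is expected from compound 1 to compound 3. The value of compound 3 in this assay is expected to be 4.3 10^-6 cm/s, within a range of 2.4 10^-6 cm/s to 7.5 10^-6 cm/s, with the step of no change at the digits printed from compound 1 to compound 3 (within the scatter) expected to stay inside the usual scatter.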

Compound 3, apparent permeability: 4.1 10^-6 cm/s
Compound 3: middle estimate off by 1.0-fold (0.02 log units), on the high side, and the stated range covers the measured number.
By their numbers in this assay, from the lowest: compound 2; then compounds 3 and 1 (each within the scatter of the next).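

In this assay, among these compounds, reversing both stereocentres of compound 1 gives a 1.0-fold lower number from compound 1 to compound 3 (0.02 log units; within the scatter), the first step that can be read from one structural change. For this one mirror-image pair, then, the read-out does not separate the two drawn configurations, with the saturated chain carbon and the saturated ring carbon reversed together and the number staying inside the usual scatter. The reading is free of any other structural change, and it applies to this position and this pair alone, not to stereocentres elsewhere in the series: the fact that compounds 1 and 3 differ only in the configuration as drawn

The compounds shown leave open whether reversing only the chain stereocentre or only the ring stereocentre, which would give a compound that is not a mirror image of compound 1, would also stay inside the scatter. Among the compounds shown here, they also leave open how the number would respond if the hydroxyl on that chain gave way to an amine or a carboxylic acid, as the only step on record here touches configuration and no atoms or bonds.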